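This account rests on a few compounds, and the source may have more. Where it says the series, first, only, none or still open, it means among the compounds named here.

Of the compounds shown here, three have so far been measured in an assay on isolated protein for inhibition of coagulation factor X (Oryctolagus cuniculus), tested at 1 uM; on this read-out higher numbers stand for more inhibition at the one concentration tested (going by the name of the read-out) and lower numbers for less inhibition. Compound 1 `O=C1[C@@H](NS(=O)(=O)c2cc3ccnc(Cl)c3s2)CCN1Cc1cc2[nH]cccc-2n1` gives 45% in this assay. Compound 2 `O=C1[C@@H](NS(=O)(=O)c2cc3ccnc(Cl)c3s2)CCN1Cc1cc2c[nH]ccc-2n1` differs from compound 1 by a group of 9 heavy atoms (7 carbon, 2 nitrogen; one five-membered aromatic ring with 1 hetero atom, one six-membered aromatic ring with 1 hetero atom) in place of a group of 9 heavy atoms (7 carbon, 2 nitrogen; one five-membered aromatic ring with 1 hetero atom, one six-membered aromatic ring with 1 hetero atom), on a saturated chain carbon bound to an amide-type nitrogen in a ring, and in this assay compound 2 gives 25%, a step of a number 20 percentage points lower from compound 1 to compound 2 (beyond the scatter). Compound 3 `CC(C)(C)c1ccc(S(=O)(=O)N[C@H]2CCN(Cc3cc4[nH]cccc-4n3)C2=O)cc1` has a different group on the sulfonyl sulfur; its difference from compound 1 is a group of 10 heavy atoms (10 carbon; one six-membered aromatic ring of carbon only) in place of a group of 10 heavy atoms (7 carbon, 1 nitrogen, 1 sulfur, 1 chlorine; one five-membered aromatic ring with 1 hetero atom, one six-membered aromatic ring with 1 hetero atom), on a sulfonyl sulfur, and in this assay compound 3 gives 22%, a step of a number 23 percentage points lower from compound 1 to compound 3 (beyond the scatter). Compound 4 `CC(C)(C)c1ccc(S(=O)(=O)N[C@H]2CCN(Cc3cc4c[nH]ccc-4n3)C2=O)cc1` has not yet been measured. Among the measured compounds shown here, it differs from compound 3 by a group of 9 heavy atoms (7 carbon, 2 nitrogen; one five-membered aromatic ring with 1 hetero atom, one six-membered aromatic ring with 1 hetero atom) in place of a group of 9 heavy atoms (7 carbon, 2 nitrogen; one five-membered aromatic ring with 1 hetero atom, one six-membered aromatic ring with 1 hetero atom), on a saturated chain carbon bound to an amide-type nitrogen in a ring, the same change as the one between compound 1 and compound 2, made at the same place. That change lowered the read-out once, by a number 20 percentage points lower from compound 1 to compound 2 (beyond the scatter). A step of similar direction but smaller size is expected from compound 3 to compound 4, namely a number 14 percentage points lower from compound 3 to compound 4 (beyond the scatter), because compound 3 already starts low at 22% and a percentage of inhibition cannot fall far below nothing. On this basis compound 4 is expected to give about 8% in this assay, estimated to lie between 0% and 22%.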

Compound 4, a percentage reported as inhibition, at one concentration (the size of the read-out at that concentration, not a potency): 14%
Compound 4: middle estimate off by 6 percentage points, on the low side, within the range that was stated.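

In this assay, exchanging the two-ring group on the saturated chain carbon bound to an amide-type nitrogen in a ring for its rearranged form, with the same atoms joined differently, gives a number 8 percentage points lower from compound 3 to compound 4 (within the scatter), and this step can be set beside the same change on the other core: the same change on two cores in this assay, a number 20 percentage points lower (beyond the scatter) from compound 1 to compound 2 and a number 8 percentage points lower (within the scatter) from compound 3 to compound 4, 12 percentage points apart, within the scatter of two such steps. Putting the all-carbon group on the sulfonyl sulfur in place of the chlorine-containing two-ring group gives a number 11 percentage points lower from compound 2 to compound 4 (beyond the scatter), and this step too can be compared with its earlier counterpart: the same change on two cores in this assay, a number 23 percentage points lower (beyond the scatter) from compound 1 to compound 3 and a number 11 percentage points lower (beyond the scatter) from compound 2 to compound 4, 12 percentage points apart, within the scatter of two such steps. Both changes therefore carried from one core to the other without a clear difference in size, but the new two-ring step alone does not show a real drop on this core, and two pairs cannot establish a rule for the wider series.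

Going by these compounds, it remains open whether these steps would hold with a group on the sulfonyl sulfur carrying an amine or a carboxylic acid. Each reading comes from a single concentration, so the potency of these compounds also remains open.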